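Aryl urea variation in a cell growth inhibition series

The source may report more compounds than this note shows. Statements on the series, on what has been measured and on what is new or still open speak of the compounds shown alone.

Compound 1 `O=C(Nc1ccccc1)Nc1ccc(Oc2ccc(-c3ncc[nH]3)cc2)cc1`: 7.09%
Compound 2 `O=C(Nc1ccc(Oc2ccc(-c3ncc[nH]3)cc2)cc1)Nc1ccc(Cl)c([N+](=O)[O-])c1`: 12.4%
Compound 3 `Cc1ccc(NC(=O)Nc2ccc(Oc3ccc(-c4ncc[nH]4)cc3)cc2)cc1`: 24.6%

Three ureas built on one shared core were tested in a functional assay on A549 cells (Homo sapiens) for inhibition, read by MTT assay and WST assay, with a stated time of 72 h, tested at 10 uM; on this read-out lower numbers stand for less inhibition of growth and higher numbers for more inhibition of growth at the one concentration tested. Compound 1 gives 7.09%, compound 2 gives 12.4%, and compound 3 gives 24.6%. Compound 3 stands highest of the three: the step of a number 12.2 percentage points higher from compound 2 to compound 3 (beyond the scatter) and the step of a number 17.5 percentage points higher from compound 1 to compound 3 (beyond the scatter) both lie beyond the scatter, whereas the step of a number 5.3 percentage points higher from compound 1 to compound 2 (within the scatter) does not.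

Compound 4 `O=C(Nc1ccc(Oc2ccc(-c3ncc[nH]3)cc2)cc1)Nc1cc(Br)cc(C(F)(F)F)c1` has not yet been measured. It differs from compound 3 in one place: 3-bromo-5-(trifluoromethyl)phenyl in place of 4-methylphenyl on an amide-type nitrogen. Of the measured steps, the one bearing most directly on this exchange is a number 12.2 percentage points higher from compound 2 to compound 3 (beyond the scatter), in which a 4-chloro-3-nitrophenyl group on the same nitrogen gave way to the 4-methylphenyl group. The step of a number 5.3 percentage points higher from compound 1 to compound 2 (within the scatter) shows that placing a 4-chloro-3-nitrophenyl group where plain phenyl had been changed little. Taken in reverse, moving away from the 4-methylphenyl group toward a differently substituted aryl group points to a modest drop, though the new group is not the same as any measured one, so the size is uncertain. Compound 4 is therefore expected to give 17%, within a range from 5% to 32%. This amounts to an expected step of a number 7.6 percentage points lower from compound 3 to compound 4 (within the scatter).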

Compound 4, percent growth inhibition at one concentration: 44.1%
Estimate against measurement, compound 4: 27.1 percentage points below; the whole stated range lies below it.
By their numbers in this assay, from the lowest: compounds 1 and 2 (each within the scatter of the next); then compound 3; then compound 4.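

In this assay, the amide-type nitrogen proves able to carry an aryl group that lifts the number clearly past the best earlier compound, with a number 19.5 percentage points higher from compound 3 to compound 4 (beyond the scatter) as the step. The earlier compounds had shown a substituted aryl group doing little over plain phenyl in the case of 4-chloro-3-nitrophenyl, yet a number 31.7 percentage points higher from compound 2 to compound 4 (beyond the scatter) and a number 37 percentage points higher from compound 1 to compound 4 (beyond the scatter) are both large, so the result here depends on which substituted aryl group is present and not simply on the ring bearing substituents. The change from 4-methylphenyl to 3-bromo-5-(trifluoromethyl)phenyl adds bromine and fluorine and leaves both groups with no hydrogen-bond donors or acceptors, but no measurement shown here accounts for the rise.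

The compounds shown leave open whether the bromine or the trifluoromethyl group alone on the phenyl ring would keep this higher number, and whether an amine or a carboxylic acid on that ring would move it the same way. They also leave open whether this order of the compounds would hold at any concentration other than the single one tested.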